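A few compounds are considered here, and "the series" means these few. Any claim that something is new, unique, unknown or untested is made for them only; others in the source may bear on it.

Three compounds have so far been measured in an assay on HEK293 cells for inhibition of acid ceramidase (Homo sapiens), with a stated time of 10 min; on this read-out higher numbers stand for weaker inhibition and lower numbers for stronger inhibition:

Compound 1, `COc1ccc(CCCCNC(=O)n2c(=O)oc3ccccc32)cc1`, gives 63 nM.
Compound 2, `O=C(NCCCCc1ccc(F)cc1)n1c(=O)oc2ccccc21`, gives 75 nM.
Compound 3, `COc1ccc(-c2ccc3oc(=O)n(C(=O)NCCCCc4ccccc4)c3c2)cc1`, gives 67 nM.

Compound 1 and compound 2 share one core and differ in a single spot: fluoro in place of methoxy on an aromatic carbon. Their readings sit close together, and the step reads a 1.2-fold higher number from compound 1 to compound 2 (0.08 log units; within the scatter). Compound 3 carries a different core from compound 1; how the two cores differ is not broken down here, and the values of compound 1 and compound 3 lie close to one another, as do those of compound 2 and compound 3.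

The unmeasured compound 4, `O=C(NCCCCc1ccccc1)n1c(=O)oc2ccc(-c3ccc(F)cc3)cc21`, is built from compound 3 by the same exchange: fluoro in place of methoxy on an aromatic carbon. The spot where the exchange happens is described in exactly the same words for both pairs, so this is the same change carried over to another core. Among the compounds with values here, only one measured instance of this exchange exists, and it moved the read-out very little. The expected step is a 1.2-fold higher number from compound 3 to compound 4 (0.08 log units; within the scatter). Compound 4 is therefore expected to give about 80 nM, with 40 nM and 160 nM as the lower and upper ends of the likely range. Within the data shown here, this expectation rests on compound 3 at 67 nM together with the one measured precedent, a 1.2-fold higher number from compound 1 to compound 2 (0.08 log units; within the scatter).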

Compound 4, half-maximal inhibitory concentration in the acid ceramidase assay: 56 nM
The estimate for compound 4 lay 1.4-fold (0.15 log units) above the measured number; the measured number falls inside the stated range.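

In the acid ceramidase assay compound 4 gives 56 nM. In the acid ceramidase assay, fluoro in place of methoxy on an aromatic carbon gives a 1.2-fold lower number from compound 3 to compound 4 (0.08 log units; within the scatter), so on this second core the exchange again leaves the read-out within the usual scatter of repeated measurements. Set side by side, the two instances of the change do not differ in any way that can be told apart: the same change on two cores in the acid ceramidase assay, a 1.2-fold higher number (0.08 log units; within the scatter) from compound 1 to compound 2 and a 1.2-fold lower number (0.08 log units; within the scatter) from compound 3 to compound 4, 1.4-fold (0.15 log units) apart, within the scatter of two such steps. Within the data shown here, this shows that on these two cores the exchange hardly moves the reading, but with only two small steps it cannot show that fluoro is better or worse than methoxy, nor that the same would hold on any other core.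

In a physicochemical assay for metabolic stability, read by HPLC, in phosphate buffer, at pH 7.4, tested at 10 uM (on this read-out higher numbers stand for a longer-lived compound and lower numbers for a shorter-lived compound), compound 3 gives 2.93 h. As far as these compounds go, in the physicochemical assay, compound 4 gives > 5 h, which is a limit of the assay and not a number, so how far its half-life lies from that of compound 3 stays open: the limit of > 5 h in the physicochemical assay, at which 1 of the 2 values shown sits. Also open, from the compounds shown here alone, is whether a group of a very different kind at the same spot, such as an amine or a carboxylic acid, would leave the reading in the acid ceramidase assay just as unmoved as fluoro and methoxy do.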